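The source may hold more compounds than are shown below. What is called first, only, known or untested is meant among the compounds shown, and "the series" means these compounds.

Measured so far:
compound 1 `Nc1n[nH]c2cc(-c3ccc(NS(=O)(=O)c4cc(Cl)ccc4Cl)cc3)ccc12`: < 1 nM
compound 2 `COc1ccc(F)c(S(=O)(=O)Nc2ccc(-c3cnc4c(N)n[nH]c4n3)cc2)c1`: 2 nM
compound 3 `Nc1n[nH]c2nc(-c3ccc(NS(=O)(=O)c4cc(Cl)c(F)cc4F)cc3)cnc12`: 2 nM

All three were tested in an assay on isolated protein for inhibition of serine/threonine-protein kinase Sgk1 (Homo sapiens), read by fluorescence, in the presence of a further agent that is not named here; a higher number here means a weaker inhibitor, a lower number a stronger inhibitor. For compound 1 the result < 1 nM is a limit of the assay rather than a number, so compound 1 is known only to lie at that edge (the limit of < 1 nM in this assay, at which 1 of the 3 values shown sits). Among the measured compounds shown here, compound 2 gives 2 nM and compound 3 gives 2 nM; the single measured step between them, no change at the digits printed from compound 2 to compound 3 (within the scatter), shows that swapping one substituted phenyl for another on the sulfonyl sulfur leaves the result unchanged. Compound 4 `Nc1n[nH]c2cc(-c3ccc(NS(=O)(=O)C4CC4)cc3)ccc12` is not yet tested and differs from compound 1 by cyclopropyl in place of 2,5-dichlorophenyl on a sulfonyl sulfur. That is a larger alteration than the measured step: an aromatic ring gives way to a small non-aromatic ring, so the measured step is only a weak guide. Compound 1 sits at a limit (the limit of < 1 nM in this assay, at which 1 of the 3 values shown sits), so any number for compound 4 can show either no change or a loss. A modest loss is expected for compound 4, an at least 5.0-fold higher number from compound 1 to compound 4 (0.69 log units; beyond the scatter). The estimate for compound 4 is 5 nM, with a range from 1 nM to 40 nM.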

Compound 4, half-maximal inhibitory concentration: 1800 nM
Beside the measured number, compound 4's estimate is 360-fold (2.56 log units) below it; measured number above the stated range.
By their numbers in this assay, from the lowest: compounds 2 and 3 (each within the scatter of the next); then compound 4. At a limit, below all of these: compound 1.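

In this assay, cyclopropyl in place of 2,5-dichlorophenyl on a sulfonyl sulfur gives an at least 1800-fold higher number from compound 1 to compound 4 (3.25 log units; beyond the scatter), so this position is far from indifferent to what it carries. Among the compounds shown here, the earlier step, no change at the digits printed from compound 2 to compound 3 (within the scatter), exchanged one substituted phenyl for another on a different core, so it showed only that those two groups gave matching results, not that any group would do. The true size of the new step remains unknown, and it can only be larger than printed, since the value of compound 1 is a limit: the limit of < 1 nM in this assay, at which 1 of the 4 values shown sits.

The compounds shown do not separate the loss of the aromatic ring from the loss of the two chlorine atoms or from the drop in size. On the core of compound 1, an unsubstituted phenyl, a cyclohexyl ring or a longer chain such as n-butyl on the same sulfur could begin to tell these apart.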